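All at the Limit: Removing a Methyl on Two Cores

The source may report more compounds than this note shows. Statements on the series, on what has been measured and on what is new or still open speak of the compounds shown alone.

Compound 1 `CCOc1ncnc2c1ncn2C[C@@H]1C[C@H](CO)c2ccccc21` and compound 2 `COc1ncnc2c1ncn2C[C@@H]1C[C@H](CO)c2ccccc21` share one core, while compound 3 `CCCCCC#Cc1cn([C@H]2C[C@H](O)[C@@H](CO)O2)c(=O)[nH]c1=O` and compound 4 `CCCCC#Cc1cn([C@H]2C[C@H](O)[C@@H](CO)O2)c(=O)[nH]c1=O` share another; the difference between the two cores is not broken down here. In an ADME assay on L1210/0 cells (Mus musculus) for cytotoxicity, with a stated time of 48 h (on this read-out lower numbers stand for stronger inhibition and higher numbers for weaker inhibition), compound 1 gives only a limit of the assay, > 200000 nM. Compound 2 likewise reaches only a limit, > 200000 nM. Compound 3 too stops at a limit, > 200000 nM. The change from compound 1 to compound 2 is hydrogen in place of methyl on a saturated chain carbon bound to an oxygen on an aromatic ring, and the step it made, a step that the two limits leave unreadable from compound 1 to compound 2, cannot be sized since both ends sit at the limit of > 200000 nM in this assay, at which 3 of the 3 values shown sit. The change from compound 3 to compound 4 is hydrogen in place of methyl on a saturated chain carbon, four bonds along the chain from a triple-bonded carbon: the same kind of change, though the place differs, being on a saturated chain carbon bound to an oxygen on an aromatic ring in the first pair and on a saturated chain carbon, four bonds along the chain from a triple-bonded carbon in the second. For compound 4 the expected step in this assay is a step that the limit leaves unreadable from compound 3 to compound 4. This rests on compound 1 and compound 2 both sitting at the limit of > 200000 nM in this assay, at which 3 of the 3 values shown sit, which left a step that the two limits leave unreadable from compound 1 to compound 2 unreadable. Compound 4 is therefore estimated at 300000 nM, between 100000 nM and 1000000 nM, most likely reported again only as a limit.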

Compound 4, half-maximal inhibitory concentration: > 200000 nM
Compound 4: only a limit was reported; the forecaster's own chance of this, stated with the estimate: 85%; the middle value is on the limit's open side.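

In this assay compound 4 gives > 200000 nM, which is a limit and not a number. Compound 3 also stops at a limit, so no step can be read between compound 3 and compound 4. Left open is whether hydrogen in place of methyl changes this read-out at all on either core, as no compound shown gives an actual number.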